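Swapping cycloheptyl for phenyl: estimating growth inhibition

The compounds below may be only part of what the source reports. "The series", "measured", "known", "first", "only" and "open" are said of these compounds alone.

Compound 1 `c1ccc(Oc2cccc(NC3=NCCO3)c2)cc1` gives 9600 nM
Compound 2 `O=C(CCl)NC(=O)Nc1cccc(OC2CCCC2)c1` gives 3500 nM
Compound 3 `O=C(CCl)NC(=O)Nc1cccc(OC2CCCCCC2)c1` gives 4200 nM

In a functional assay on M21 cells (Homo sapiens) for inhibition, read by sulforhodamine B assay, with a stated time of 48 h (on this read-out lower numbers stand for stronger inhibition of growth and higher numbers for weaker inhibition of growth), compound 3 gives 4200 nM and sits level with compound 2 within the scatter, while compound 1 stands clearly higher at 9600 nM on a different core. The next molecule, compound 4 `O=C(CCl)NC(=O)Nc1cccc(Oc2ccccc2)c1`, keeps the core of compound 3 and carries phenyl in place of cycloheptyl on an oxygen on an aromatic ring. For the measured compounds named here, the one measured step on that same oxygen is a 1.2-fold higher number from compound 2 to compound 3 (0.08 log units; within the scatter) and swaps cyclopentyl for cycloheptyl. It therefore shows that these two non-aromatic rings give matching numbers, but it says nothing direct about an aromatic ring. Compound 1 also has phenyl on an oxygen at 9600 nM but its core differs, so it offers only a weak hint toward a higher number. Going by the values given here, no measured step shows what phenyl does on this core, so no change beyond the scatter is firmly expected in this assay and the range must stay wide. The expected step is a 1.1-fold higher number from compound 3 to compound 4 (0.03 log units; within the scatter) with only a slight lean toward a higher number. For compound 4 the estimated value is 4500 nM with an expected range from 2000 nM to 10000 nM as the likely span.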

Compound 4, concentration for 50% growth inhibition: 5300 nM
Compound 4: middle estimate off by 1.2-fold (0.07 log units), on the low side; measured number inside the range.
By their numbers in this assay, from the lowest: compounds 2, 3, 4 and 1 (each within the scatter of the next, the first and the last beyond it).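

In this assay, an aromatic ring on this oxygen does not separate from the non-aromatic rings: a 1.3-fold higher number from compound 3 to compound 4 (0.10 log units; within the scatter) and a 1.5-fold higher number from compound 2 to compound 4 (0.18 log units; within the scatter), so cyclopentyl, cycloheptyl and phenyl cannot be told apart at this position on the shared core. For the compounds shown here, compound 4 also gives the first single-place comparison with compound 1, with phenyl on the oxygen in both; the change is on a nitrogen on an aromatic ring, where a group of 7 heavy atoms with no ring replaces a group of 5 heavy atoms with one five-membered non-aromatic ring, and it gives a 1.8-fold lower number from compound 1 to compound 4 (0.26 log units; within the scatter), so this change on the nitrogen cannot be told from scatter either. No supporting measurement bears on why these numbers fall as they do.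

All the compounds shown carry a ring on this oxygen, so it remains open what an open chain such as butyl, or a phenyl carrying an amine or a carboxylic acid, would give there. Also open, from the compounds shown here alone, is whether the change on the nitrogen would stay within the scatter with cyclopentyl or cycloheptyl on the oxygen in place of phenyl.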